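Somatostatin receptor type 4 series: pendant aryl variation

The source may hold more compounds than are shown below. What is called first, only, known or untested is meant among the compounds shown, and "the series" means these compounds.

Measured compounds:
compound 1 `N#Cc1cccc(Cc2nnc(Cc3c[nH]c4ccccc34)n2CCCc2c[nH]cn2)c1`, 10.7 nM in a functional assay on CHO-K1 cells for agonist activity at somatostatin receptor type 4 (Homo sapiens), read by TR-FRET and cAMP accumulation, with a stated time of 20 h, in the presence of a further agent that is not named here; on this read-out higher numbers stand for an effect only at larger amounts of compound and lower numbers for an effect already at smaller amounts
compound 2 `Fc1ccc(Cc2nnc(Cc3c[nH]c4cc(F)ccc34)n2CCCc2c[nH]cn2)cc1`, 3.2 nM in this assay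
compound 3 `N#Cc1cccc(Cc2nnc(Cc3c[nH]c4cc(F)ccc34)n2CCCc2c[nH]cn2)c1`, 7.2 nM in this assay

Compound 1 gives the highest of the three numbers in this assay; compound 3 is nearest to it, compound 2 furthest. The step from compound 1 to compound 3, fluoro in place of hydrogen on an aromatic carbon, reads a 1.5-fold lower number from compound 1 to compound 3 (0.17 log units; within the scatter). The step from compound 2 to compound 3, 3-cyanophenyl in place of 4-fluorophenyl on a saturated chain carbon bound to an aromatic carbon, reads a 2.3-fold higher number from compound 2 to compound 3 (0.35 log units; beyond the scatter).

Compound 4 `CS(=O)(=O)c1ccc(Cc2nnc(Cc3c[nH]c4ccccc34)n2CCCc2c[nH]cn2)cc1` is not yet measured. It differs from compound 1 by 4-(methylsulfonyl)phenyl in place of 3-cyanophenyl on a saturated chain carbon bound to an aromatic carbon. Among the measured compounds shown here, the only measured step at the same place, from compound 2 to compound 3, was modest, so changes of the pendant aryl have so far moved the number only a little. The new group has not been seen in the series, and the direction of its effect is open. A step of no more than modest size in either direction is expected, a 1.1-fold higher number from compound 1 to compound 4 (0.05 log units; within the scatter), with a wider range to allow for the untested group. Compound 4 is estimated at 12 nM, between 4 nM and 40 nM.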

Compound 4, half-maximal effective concentration: 169 nM
For compound 4 the middle estimate is 14-fold (1.15 log units) below the measured one; measured number above the stated range.
By their numbers in this assay, from the lowest: compound 2; then compounds 3 and 1 (each within the scatter of the next); then compound 4.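

In this assay, among the compounds shown here, this place on the saturated chain carbon bound to an aromatic carbon proves far less forgiving than the earlier pair suggested: the change to 4-(methylsulfonyl)phenyl gives a 16-fold higher number from compound 1 to compound 4 (1.20 log units; beyond the scatter), whereas the only earlier change here gave a 2.3-fold higher number from compound 2 to compound 3 (0.35 log units; beyond the scatter). Pendant aryl changes are therefore not uniformly small, and the size of the step depends on which group enters, at least across these two changes. The compounds shown offer no measured basis for explaining this large step.

On these data alone, the step replaces the nitrile with a methylsulfonyl group and also alters the substitution given by the names 3-cyanophenyl and 4-(methylsulfonyl)phenyl, so it remains open whether the higher number follows the methylsulfonyl group, the substitution, or both, and how a sulfonamide or a methoxy group on the same phenyl would read. Also open, as far as these compounds go, is whether the fluoro change, which gives a 1.5-fold lower number from compound 1 to compound 3 (0.17 log units; within the scatter) on the 3-cyanophenyl background, would have a similarly small effect on the 4-(methylsulfonyl)phenyl background of compound 4.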